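Aryl variation on the carbonyl of the boron-containing chalcone core

The source may hold more compounds than are shown below. What is called first, only, known or untested is meant among the compounds shown, and "the series" means these compounds.

Measured so far in a functional assay on MDA-MB-231 cells (Homo sapiens) for cytotoxicity, read by MTT assay, with a stated time of 48 h; on this read-out lower numbers stand for stronger inhibition and higher numbers for weaker inhibition:
compound 1 `O=C(/C=C/c1ccc2c(c1)B(O)OC2)c1ccccc1` gives 2300 nM
compound 2 `O=C(/C=C/c1ccc2c(c1)B(O)OC2)c1ccco1` gives 7300 nM
compound 3 `Cn1cccc1C(=O)/C=C/c1ccc2c(c1)B(O)OC2` gives > 100000 nM

The value of compound 3 is a limit of the assay, not a number; it is the one entry at the limit of > 100000 nM in this assay, at which 1 of the 3 values shown sits. Compound 3 therefore stands at the weak end of the three, below anything measured with a number. The two steps into it were large: an at least 43-fold higher number from compound 1 to compound 3 (1.63 log units; beyond the scatter) and an at least 13-fold higher number from compound 2 to compound 3 (1.13 log units; beyond the scatter). The step between the two numbered compounds was smaller: a 3.2-fold higher number from compound 1 to compound 2 (0.50 log units; beyond the scatter).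

Next is compound 4 `Cc1ccc(C(=O)/C=C/c2ccc3c(c2)B(O)OC3)cc1`. It differs from compound 3 in one place: 4-methylphenyl in place of 1-methyl-1H-pyrrol-2-yl on a carbonyl carbon. This reverses the large loss seen on going to the 1-methyl-1H-pyrrol-2-yl compound and returns to a six-membered carbon ring, as in compound 1. A large drop in number is therefore expected for this assay, in the direction of stronger inhibition. Compound 4 is expected near 2500 nM, with a range from 800 nM to 8000 nM. The expected step of an at least 40-fold lower number from compound 3 to compound 4 (1.60 log units; beyond the scatter) rests on compound 1, whose value 2300 nM is the closest measured comparison.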

Compound 4, half-maximal inhibitory concentration: 6500 nM
Compound 4: the middle estimate sits 2.6-fold (0.41 log units) below what was measured; low and high end bracket the measured number.
By their numbers in this assay, from the lowest: compound 1; then compounds 4 and 2 (each within the scatter of the next). At a limit, above all of these: compound 3.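

The entry for compound 3 in this assay is a limit and not a number: the limit of > 100000 nM in this assay, at which 1 of the 4 values shown sits.

A six-membered aromatic ring of carbon only on the carbonyl carbon restores a numbered result, with an at least 15-fold lower number from compound 3 to compound 4 (1.18 log units; beyond the scatter), so the shared core does not by itself carry the loss seen in compound 3. The position is still sensitive to a small addition, since methyl in place of hydrogen on an aromatic carbon gives a 2.8-fold higher number from compound 1 to compound 4 (0.45 log units; beyond the scatter), while the 4-methylphenyl and furan-2-yl compounds cannot be separated, with a 1.1-fold lower number from compound 2 to compound 4 (0.05 log units; within the scatter).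

Going by these compounds, it remains open whether the effect of that methyl is specific to it or would also appear with a methoxy group or a chlorine on the same ring. On these data alone, it is also open whether the loss in compound 3 follows the ring itself or its methyl, which a 1H-pyrrol-2-yl group would separate.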